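Chloro to Methoxy on the Carbonyl-Bearing Ring: Compound 4

This account rests on a few compounds, and the source may have more. Where it says the series, first, only, none or still open, it means among the compounds named here.

Compound 1, `COc1cc(-c2nnc3n2NC(c2ccco2)C(C(=O)c2ccc(Cl)cc2)S3)cc(OC)c1OC`, gives > 100000 nM in a functional assay on MCF7 cells (Homo sapiens) for cytotoxicity, read by MTT assay, with a stated time of 48 h (a higher number here means a weaker inhibitor, a lower number a stronger inhibitor), which is a limit of the assay rather than a number.
Compound 2, `COc1cc(-c2nnc3n2NC(c2cccs2)C(C(=O)c2ccc(F)cc2)S3)cc(OC)c1OC`, gives 43700 nM in this assay.
Compound 3, `COc1cc(C(=O)C2Sc3nnc(-c4cc(OC)c(OC)c(OC)c4)n3NC2c2cccs2)cc(OC)c1OC`, gives 71000 nM in this assay.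

Compound 1 stands only at a limit, so its place among the measured numbers cannot be fixed. Compound 4, `COc1ccc(C(=O)C2Sc3nnc(-c4cc(OC)c(OC)c(OC)c4)n3NC2c2ccco2)cc1`, differs from compound 1 by methoxy in place of chloro on an aromatic carbon. Among the measured compounds shown here, the one measured step, a 1.6-fold higher number from compound 2 to compound 3 (0.21 log units; within the scatter), alters a different group on the carbonyl carbon and stays within the scatter; no measured step touches chloro or methoxy. For compound 4 in this assay, no step beyond the scatter is therefore expected, and the result may again be a limit. Compound 4 is estimated at 100000 nM, between 40000 nM and 300000 nM. The expected step reads a number no higher from compound 1 to compound 4 (the limit leaves the size open).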

Compound 4, half-maximal inhibitory concentration: > 100000 nM
Compound 4 ended at the assay's limit (the forecaster's own chance of this, stated with the estimate: 50%); the middle value lies on the limit itself.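

Among the compounds shown here, compound 1 and compound 4 both end at a limit rather than a number, so no step between them can be read: the limit of > 100000 nM in this assay, at which 2 of the 4 values shown sit.

As far as these compounds go, whether methoxy in place of chloro changes the result at all remains open.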